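A few compounds are considered here, and "the series" means these few. Any claim that something is new, unique, unknown or untested is made for them only; others in the source may bear on it.

Measured compounds:
compound 1, `O=C(c1cccc(Cl)c1)N1CCC(NS(=O)(=O)c2cc(S(=O)(=O)c3ccccc3)ccc2C(F)(F)F)CC1`, 870 nM
compound 2, `O=S(=O)(NC1CCN(S(=O)(=O)c2cccc(-c3nnn[nH]3)c2)CC1)c1cc(S(=O)(=O)c2ccccc2)ccc1C(F)(F)F`, 1200 nM

In an assay on U2OS cells for inhibition of secreted frizzled-related protein 1 (Homo sapiens), read by a luciferase reporter, with a stated time of 18 h (on this read-out higher numbers stand for an effect only at larger amounts of compound and lower numbers for an effect already at smaller amounts), compound 1 gives 870 nM, the lower of the two numbers, while compound 2 gives 1200 nM; the two values lie within the usual scatter of one another, so they show no real difference between the compounds. Compound 3, `CC(C)(C)OC(=O)N1CC[C@@H](C(=O)N2CCC(NS(=O)(=O)c3cc(S(=O)(=O)c4ccccc4)ccc3C(F)(F)F)CC2)C1`, has not yet been measured in this assay. It differs from compound 1 in one place: 1-(tert-butoxycarbonyl)pyrrolidin-3-yl in place of 3-chlorophenyl on a carbonyl carbon. Going by the values given here, no measured pair in this set carries the same change, so there is nothing here to calibrate it against. The expected step is a 2.1-fold higher number from compound 1 to compound 3 (0.32 log units; beyond the scatter), a small rise in the number, roughly at the edge of the usual scatter rather than clearly beyond it. For compound 3 the estimate in this assay is therefore 1800 nM, with a plausible range from 600 nM to 5500 nM.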

Compound 3, half-maximal effective concentration: 80 nM
Compound 3: the middle estimate sits 23-fold (1.35 log units) above what was measured; measured number below the stated range.
By their numbers in this assay, from the lowest: compound 3; then compounds 1 and 2 (each within the scatter of the next).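

In this assay, the group on the carbonyl carbon whose other neighbour is the amide-type nitrogen in a ring has a strong influence on the read-out: 1-(tert-butoxycarbonyl)pyrrolidin-3-yl in place of 3-chlorophenyl gives an 11-fold lower number from compound 1 to compound 3 (1.04 log units; beyond the scatter). This single pair shows that an aromatic ring at this position is not required for a low number, and that a larger, non-aromatic group carrying a defined stereocentre is accepted here. Nothing measured here accounts for the size of this step.

The compounds shown leave open which part of the entering group matters: the tert-butoxycarbonyl group, the pyrrolidine ring or its stereocentre. A free secondary amine in the pyrrolidine ring, the opposite stereoisomer or a plain cyclopentyl group at this carbonyl would each address a different part of that question.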